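Aryl swap on the urea nitrogen of a pyrazole core

The source may hold more compounds than are shown below. What is called first, only, known or untested is meant among the compounds shown, and "the series" means these compounds.

Compound 1 `CCN1CCc2c(c(C)nn2C(=O)Nc2ccc(Br)cc2)C1` gives 81.6% in a functional assay on the whole organism (strain Swiss albino) for inhibition, with Mus musculus as the target, in the formalin test, with a stated time of 30 min, at a dose of 100 mg/kg; a higher number here means more inhibition at the dose given (going by the name of the read-out), a lower number less inhibition.
Compound 2 `CCN1CCc2c(c(C(C)(C)C)nn2C(=O)Nc2ccc(Br)cc2)C1` gives 72.1% in this assay.

Within the data shown here, compound 2 stands lowest of the two numbers measured so far, its nearest neighbour being compound 1; the one measured step, a number 9.5 percentage points lower from compound 1 to compound 2 (within the scatter), stays within the scatter. Compound 3 `CCN1CCc2c(c(C(C)(C)C)nn2C(=O)Nc2cc(C)ccc2C)C1` has not yet been measured. It differs from compound 2 in one place: 2,5-dimethylphenyl in place of 4-bromophenyl on an amide-type nitrogen. Among the measured compounds shown here, no measured step touches this part of the molecule; the only step seen concerns the substituent on the core, and it was small. Nothing in the data therefore points to a change beyond the scatter in this assay for compound 3, and the step of a number 2.1 percentage points lower from compound 2 to compound 3 (within the scatter) is expected to be modest. Compound 3 is estimated to give 70%, within a range from 50% to 85%.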

Compound 3, a percentage reported as inhibition, in the whole organism at one dose (the size of the read-out at that dose, not a potency): 15.7%
For compound 3 the middle estimate is 54.3 percentage points above the measured one; measured number below the stated range.
By their numbers in this assay, from the lowest: compound 3; then compounds 2 and 1 (each within the scatter of the next).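

In this assay the aryl group on the amide-type nitrogen turns out to count for far more than the substituent on the core: 2,5-dimethylphenyl in place of 4-bromophenyl gives a number 56.4 percentage points lower from compound 2 to compound 3 (beyond the scatter) while the core change gave only a number 9.5 percentage points lower from compound 1 to compound 2 (within the scatter) in the earlier pair. This single exchange takes away the bromine and brings in two methyl groups at once, and the step alone cannot separate these two parts of the change. No measurement at hand accounts for the size of this drop.

Still open, from the compounds shown here alone, is whether a phenyl ring carrying a single methyl group, or a chlorine or methoxy group in place of the bromine, would stay near compound 2 or fall towards compound 3. Also open, going by these compounds, is whether 2,5-dimethylphenyl would cost as much on the methyl-bearing core of compound 1.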